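Swapping the aryl group on the pyrazole-type nitrogen

The source may report more compounds than this note shows. Statements on the series, on what has been measured and on what is new or still open speak of the compounds shown alone.

Measured so far:
compound 1, `CC(C)c1ccc(-n2nc(C(F)(F)F)cc2CNC(=O)Nc2cccc3[nH]ncc23)cc1`: 4.1 nM
compound 2, `Cn1ncc2c(NC(=O)NCc3cc(C(F)(F)F)nn3-c3cccc(F)c3)cccc21`: 7 nM

Both compounds were tested in an assay on CHO-K1 cells for antagonist activity at transient receptor potential cation channel subfamily V member 1 (Homo sapiens), read by FLIPR and calcium flux, with a stated time of 6 min; on this read-out higher numbers stand for weaker inhibition and lower numbers for stronger inhibition. Compound 1 gives 4.1 nM and compound 2 gives 7 nM; the two numbers lie within the usual scatter of each other, so neither can be called stronger or weaker than the other on this evidence.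

Compound 3, `Cn1ncc2c(NC(=O)NCc3cc(C(F)(F)F)nn3-c3ccc(C(C)(C)C)cc3)cccc21`, has not yet been measured. It differs from compound 2 in one place: 4-(tert-butyl)phenyl in place of 3-fluorophenyl on an aromatic nitrogen. Among the measured compounds shown here, no step between two measured compounds covers this exact change, so the expectation rests on what the two measured values show. Compound 1 gives 4.1 nM while carrying a different group on the same aromatic nitrogen, which suggests that this position tolerates variation without a large shift. Compound 3 is therefore expected to land close to compound 2, with a step of a 1.4-fold lower number from compound 2 to compound 3 (0.15 log units; within the scatter), no larger than the scatter. The estimate for compound 3 is 5 nM, within a range from 1.5 nM to 16 nM.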

Compound 3, inhibition constant: 13.2 nM
Compound 3: the middle estimate sits 2.6-fold (0.42 log units) below what was measured; low and high end bracket the measured number.
By their numbers in this assay, from the lowest: compounds 1, 2 and 3 (each within the scatter of the next, the first and the last beyond it).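

In this assay putting 4-(tert-butyl)phenyl in place of 3-fluorophenyl on the aromatic nitrogen gives a 1.9-fold higher number from compound 2 to compound 3 (0.28 log units; within the scatter) and so this position takes a group with more heavy atoms and no fluorine without a shift that stands out from the scatter. Among the compounds shown here, this is the first direct comparison at this position with the rest of the molecule held the same, since compound 1 and compound 2 differ in more than one place. Nothing measured here offers an explanation for this result.

From the compounds shown here alone, it remains open whether this tolerance extends to aryl groups of another kind on this nitrogen, such as a phenyl ring carrying a carboxylic acid or an amine. Going by these compounds, it is also open whether a plain butyl chain, with no aromatic ring at all, would be accepted there.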